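This account rests on a few compounds, and the source may have more. Where it says the series, first, only, none or still open, it means among the compounds named here.

Compound 2 `O=C(NCc1ccc(S(=O)(=O)N2CCCCC2)cc1)c1ccn2ccnc2c1` gives 1800 nM in an assay for inhibition of Nicotinamide phosphoribosyltransferase (Homo sapiens), read by mass spectrometry, with stated times of 15 min and 30 min (on this read-out higher numbers stand for weaker inhibition and lower numbers for stronger inhibition), the higher of the two numbers recorded; compound 1 `O=C(NCc1ccc(S(=O)(=O)N2CCCCC2)cc1)c1cc2cnccc2s1` gives 150 nM in this assay. Compound 3 `O=C(NCc1ccc(S(=O)(=O)N2CCCCC2)cc1)c1cc2cccnc2s1` has not yet been measured. It differs from compound 2 by a group of 9 heavy atoms (7 carbon, 1 nitrogen, 1 sulfur; one five-membered aromatic ring with 1 hetero atom, one six-membered aromatic ring with 1 hetero atom) in place of a group of 9 heavy atoms (7 carbon, 2 nitrogen; one five-membered aromatic ring with 2 hetero atoms, one six-membered aromatic ring with 1 hetero atom), on a carbonyl carbon. Going by the values given here, the one measured step that bears on this change runs the opposite way in kind: a 12-fold higher number from compound 1 to compound 2 (1.08 log units; beyond the scatter), where a group of the same make-up as the one leaving compound 3 took the place of a group of the same make-up as the one entering it. The group entering compound 3 is not the same as the group compound 1 carries, though it matches it in count, so the full return of that step is not assured. Compound 3 is therefore expected to show a lower number than compound 2, a step estimated at a 6.0-fold lower number from compound 2 to compound 3 (0.78 log units; beyond the scatter). Compound 3 is estimated at 300 nM, with a range from 80 nM to 1200 nM.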

Compound 3, half-maximal inhibitory concentration: 8 nM
Beside the measured number, compound 3's estimate is 38-fold (1.57 log units) above it, and the stated range ends above it.
By their numbers in this assay, from the lowest: compound 3; then compound 1; then compound 2.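

The earlier compounds shown here showed that this position on the carbonyl carbon responds to a change of bicyclic group. Compound 3 shows that the response is much larger than they revealed: in this assay there is a 230-fold lower number from compound 2 to compound 3 (2.35 log units; beyond the scatter), although the leaving and entering groups have the same counted hydrogen-bond donors and acceptors and neither carries a net charge. It also shows that make-up alone does not fix the number, since the groups of compound 1 and compound 3 match in every count yet there is a 19-fold lower number from compound 1 to compound 3 (1.27 log units; beyond the scatter), and nothing available explains either step.

The compounds shown leave open how the number would respond to a methyl group, a chlorine or an amine added to the group of compound 3. They also leave open whether the piperidine sulfonyl part of the shared core would tolerate another amine.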